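Alkoxy chain length on a prenylated flavanone core in MCF7 cells

This account rests on a few compounds, and the source may have more. Where it says the series, first, only, none or still open, it means among the compounds named here.

Compound 1 `CCCOc1ccc([C@@H]2CC(=O)c3cc(CC=C(C)C)c(OC)cc3O2)cc1`: 60%
Compound 2 `COc1ccc([C@@H]2CC(=O)c3cc(CC=C(C)C)c(OC)cc3O2)cc1`: 65%
Compound 3 `CCCCOc1ccc([C@@H]2CC(=O)c3cc(CC=C(C)C)c(OC)cc3O2)cc1`: 57%

Three compounds were measured in a functional assay on MCF7 cells (Homo sapiens) for inhibition, read by sulforhodamine B assay, with a stated time of 48 h, tested at 50 uM; a lower number here means less inhibition of growth, a higher number more inhibition of growth at the concentration tested; compound 4 `CCOc1ccc([C@@H]2CC(=O)c3cc(CC=C(C)C)c(OC)cc3O2)cc1` has not been measured. From compound 1 to compound 2 the change is hydrogen in place of ethyl on a saturated chain carbon bound to an oxygen on an aromatic ring, and it gave a number 5 percentage points higher from compound 1 to compound 2 (within the scatter). The same kind of change runs from compound 3 to compound 4, (hydrogen in place of ethyl on a saturated chain carbon, two bonds along the chain from an oxygen on an aromatic ring), but the place differs: in the first pair the carbon is bound to an oxygen on an aromatic ring, in the second it lies two bonds along the chain from that oxygen. The two cores differ by methyl in place of hydrogen on a saturated chain carbon, three bonds along the chain from an oxygen on an aromatic ring. Since all three measured values sit within the scatter of one another, the step from compound 3 to compound 4 is expected to be small, a number 5 percentage points higher from compound 3 to compound 4 (within the scatter), resting on the earlier step from compound 1 to compound 2 and on the values of compound 3 and compound 2. Compound 4 is therefore estimated at 62%, with a range from 50% to 74%.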

Compound 4, percent growth inhibition at one concentration: 57%
Compound 4: middle estimate off by 5 percentage points, on the high side, within the range that was stated.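

The change that shortens the chain by an ethyl carries from one core to the other without a gap beyond the scatter, with no change at the digits printed from compound 3 to compound 4 (within the scatter) in this assay: the same change on two cores in this assay, a number 5 percentage points higher (within the scatter) from compound 1 to compound 2 and no change at the digits printed (within the scatter) from compound 3 to compound 4, 5 percentage points apart, within the scatter of two such steps

The one-carbon change behaves alike, with a number 8 percentage points lower from compound 2 to compound 4 (within the scatter), and a number 3 percentage points lower from compound 1 to compound 4 (within the scatter) also stays within the scatter: the same change on two cores in this assay, a number 3 percentage points lower (within the scatter) from compound 1 to compound 3 and a number 8 percentage points lower (within the scatter) from compound 2 to compound 4, 5 percentage points apart, within the scatter of two such steps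

All these steps lie within the scatter, so the series shows only that these four chains are not told apart at the single concentration tested, not that a change of real size would carry over between cores.

The compounds shown leave open what a longer chain, such as hexyloxy, would do. They also leave open what a chain bearing an amine or a carboxylic acid would do.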